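Thiophene series at the adenosine A3 receptor: aryl swap

The source may hold more compounds than are shown below. What is called first, only, known or untested is meant among the compounds shown, and "the series" means these compounds.

Compound 1 `CC(C)(C)c1csc(N)c1C(=O)c1ccc(Cl)cc1` and compound 2 `CC(C)(C)Cc1c(-c2ccoc2)sc(N)c1C(=O)c1ccc(Cl)cc1` share one core; compound 2 carries a furan-3-yl group and a neopentyl group where compound 1 carries a tert-butyl group and a ring hydrogen. In an assay on CHO cells for displacement of a labelled ligand from adenosine receptor A3 (Homo sapiens), read by scintillation counting, tested at 10 uM (a higher number here means more inhibition at the concentration tested (going by the name of the read-out), a lower number less inhibition), compound 1 gives 1%. In this assay compound 2 gives 1%, level with compound 1 at the digits shown and within the scatter of it. Within the data shown here, no step between measured compounds is available for the move now considered. Compound 3 `CC(C)(C)Cc1c(-c2ccccn2)sc(N)c1C(=O)c1ccc(Cl)cc1` differs from compound 2 in one place: pyridin-2-yl in place of furan-3-yl on an aromatic carbon. Among the measured compounds shown here, with both measured compounds sitting at the bottom of the read-out, the only guide is that neither aryl pattern so far moved the number, so no step beyond the scatter is expected, in either direction, as a number 1 percentage points higher from compound 2 to compound 3 (within the scatter). For compound 3 in this assay the estimate is 2%, with a range from -6% to 12%.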

Compound 3, a percentage reported as inhibition, at one concentration (the size of the read-out at that concentration, not a potency): 1%
Estimate against measurement, compound 3: 1 percentage points above, within the range that was stated.
By their numbers in this assay, from the lowest: compounds 1, 2 and 3 (each within the scatter of the next).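

In this assay, among these compounds, pyridin-2-yl in place of furan-3-yl on the aromatic carbon next to the ring sulfur gives no change at the digits printed from compound 2 to compound 3 (within the scatter), the first step that can be read at this position. A five-membered and a six-membered aromatic ring, each with 1 hetero atom, are therefore not told apart here, but with both compounds at the bottom of the read-out, this says little about what the position would accept. Nothing at hand bears on the reason for this result.

From the compounds shown here alone, whether any group on this carbon can lift the read-out clear of the bottom remains open, for example an aminomethyl group or a carboxylic acid. Also open, going by these compounds, is whether a shorter chain such as ethyl in place of neopentyl would alter the outcome.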